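The source may report more compounds than this note shows. Statements on the series, on what has been measured and on what is new or still open speak of the compounds shown alone.

Compound 1 `C#CCOc1ccc(/C=C/C(=O)c2cccn2C)cc1OC` was tested in a functional assay on CCRF-CEM cells (Homo sapiens) for cytotoxicity, with a stated time of 72 h; on this read-out lower numbers stand for stronger inhibition and higher numbers for weaker inhibition. In this assay compound 1 gives only a limit, > 50000 nM, so no number is known for it. Compound 2 `C=CCc1cc(C(C)=O)ccc1OCC=C(C)C` gives 16300 nM in this assay. Compound 3 `C=CCOc1ccc(/C=C\C(=O)c2ccc(OCC=C(C)C)c(CC=C)c2)cc1OC` also gives only a limit, > 50000 nM, in this assay. These two limits are the same one, (the limit of > 50000 nM in this assay, at which 2 of the 3 values shown sit). Compound 4 `C#CCOc1ccc(/C=C/C(=O)c2cccc(Br)c2)cc1OC` has not yet been measured. It differs from compound 1 by 3-bromophenyl in place of 1-methyl-1H-pyrrol-2-yl on a carbonyl carbon. For the measured compounds named here, no measured pair shows what such a change does, so its direction is open. The step from compound 1 to compound 4 is expected to be an at least 2.0-fold lower number from compound 1 to compound 4 (0.30 log units; that floor lies within the scatter), a small gain at most. For compound 4 the estimate is 25000 nM, with a range from 6000 nM to 50000 nM, and a real chance that only a limit is reported again.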

Compound 4, half-maximal inhibitory concentration: 15200 nM
For compound 4 the middle estimate is 1.6-fold (0.22 log units) above the measured one, within the range that was stated.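

In this assay, for the compounds shown here, 3-bromophenyl in place of 1-methyl-1H-pyrrol-2-yl on a carbonyl carbon gives an at least 3.2-fold lower number from compound 1 to compound 4 (0.51 log units; beyond the scatter), the first readable step at this position. The group on this carbonyl carbon can therefore bring the read-out into the measurable range while the rest of the compound stays the same. From the compounds shown here alone, the true size of the step is unknown, because its starting point is a limit and not a number: the limit of > 50000 nM in this assay, at which 2 of the 4 values shown sit.

The compounds shown leave open whether the bromine or the change of ring accounts for this gain. A plain phenyl group at this position would separate the two.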